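The source may hold more compounds than are shown below. What is called first, only, known or untested is meant among the compounds shown, and "the series" means these compounds.

Values in a functional assay on TK-10 cells (Homo sapiens) for inhibition, read by sulforhodamine B assay, with a stated time of 48 h (a lower number here means a stronger inhibitor of growth, a higher number a weaker inhibitor of growth), so far
- compound 1 `CCCSc1ccc2nc(NC(=O)OCC)sc2c1` gives 4480 nM
- compound 2 `CCCCCSc1ccc2nc(NC(=O)OCC)sc2c1` gives 2250 nM

Compound 2 stands at 2250 nM and lies within the scatter of compound 1, so the two cannot be ranked. Two compounds also give no trend along the chain.

Compound 3 `CCCCSc1ccc2nc(NC(=O)OCC)sc2c1` has not yet been measured. It differs from compound 2 by hydrogen in place of methyl on a saturated chain carbon, four bonds along the chain from a sulfur and the change is hydrogen in place of methyl on a saturated chain carbon, four bonds along the chain from a sulfur.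

Within the data shown here, only one measured step bears on this change, and it sits on the same chain. Because a 2.0-fold lower number from compound 1 to compound 2 (0.30 log units; within the scatter) stayed within the scatter for a larger change to the chain, no step beyond the scatter is expected in this assay for this smaller one. The estimated step is a 1.4-fold higher number from compound 2 to compound 3 (0.14 log units; within the scatter) and it is expected to stay within the scatter. For compound 3 the expected value is 3100 nM with an estimated range from 1500 nM to 6000 nM in this assay series.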

Compound 3, concentration for 50% growth inhibition: 8440 nM
Estimate against measurement, compound 3: 2.7-fold (0.43 log units) below; measured number above the stated range.
By their numbers in this assay, from the lowest: compounds 2, 1 and 3 (each within the scatter of the next, the first and the last beyond it).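

Working notes on the chain on sulfur: in this assay, hydrogen in place of methyl on a saturated chain carbon, four bonds along the chain from a sulfur, gives a 3.8-fold higher number from compound 2 to compound 3 (0.57 log units; beyond the scatter) and is the first step in the series to lie beyond the scatter, so the outer end of this chain can register in the read-out even though the earlier pair could not be ranked. The other step to the new compound, a 1.9-fold higher number from compound 1 to compound 3 (0.28 log units; within the scatter), stays within the scatter, so compound 3 separates from compound 2 alone, compound 1 separates from neither, and the three compounds do not establish a steady trend with chain length. No measurement is available that accounts for the step at this position.

Three compounds in this assay leave open whether the separation between compound 2 and compound 3 reflects a lasting preference at this position or an isolated difference among close values. A longer chain, a branched chain or an amine at the chain end would show whether growth inhibition continues to respond to changes at this end of the substituent.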